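Adding a 2,4-dimethylpiperazin-1-yl group to the series

A few compounds are considered here, and "the series" means these few. Any claim that something is new, unique, unknown or untested is made for them only; others in the source may bear on it.

For the measured compounds named here, in a functional assay on A-375 cells (Homo sapiens) for antiproliferative activity (a lower number here means that less compound is needed, a higher number that more compound is needed for the effect), compound 1 `CC(=O)Nc1cn2cc(-c3cc(NC(=O)c4cc(C(F)(F)F)ccn4)ccc3C)ccc2n1` gives 280 nM and compound 2 `CC(=O)Nc1cn2cc(-c3cc(NC(=O)c4cccc(C(F)(F)F)c4)ccc3C)ccc2n1` gives 86 nM as the lower of the two numbers so far. Going by the values given here, the one measured step is a 3.3-fold lower number from compound 1 to compound 2 (0.51 log units; beyond the scatter) and it replaces 4-(trifluoromethyl)pyridin-2-yl with 3-(trifluoromethyl)phenyl on a carbonyl carbon. Compound 3 `CC(=O)Nc1cn2cc(-c3cc(NC(=O)c4cc(N5CCN(C)C[C@@H]5C)cc(C(F)(F)F)c4)ccc3C)ccc2n1` carries a different change, 2,4-dimethylpiperazin-1-yl in place of hydrogen on an aromatic carbon on an aromatic carbon of a six-membered aromatic ring of carbon only, meta to a trifluoromethyl group. Among the compounds with values here, no measured compound carries this group, so the earlier step gives only a rough scale and no direction. The expected change is a 1.7-fold lower number from compound 2 to compound 3 (0.24 log units; within the scatter) as an estimate with a slight lean towards a lower number in this assay and no firm expectation of a shift beyond the scatter. For compound 3 the estimate is 50 nM with an expected range from 12 nM to 200 nM for now.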

Compound 3, half-maximal effective concentration in the A-375 assay: 340 nM
Beside the measured number, compound 3's estimate is 6.8-fold (0.83 log units) below it; measured number outside the range, above it.
By their numbers in the A-375 assay, from the lowest: compound 2; then compounds 1 and 3 (each within the scatter of the next).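

On an aromatic carbon meta to a trifluoromethyl group, 2,4-dimethylpiperazin-1-yl in place of hydrogen raises the number in the A-375 assay, so less of the effect is obtained per unit of compound: a 4.0-fold higher number from compound 2 to compound 3 (0.60 log units; beyond the scatter). The same change comes with a much higher solubility in a physicochemical assay for solubility, in phosphate buffer, at pH 7; a higher number here means a more soluble compound, a lower number a less soluble compound: the measured solubility of compound 2, < 400 nM, and of compound 3, 122000 nM, an at least 300-fold higher number (2.48 log units; beyond the scatter) The value of compound 2 in the physicochemical assay, < 400 nM, is a limit of the assay and not a number. In the physicochemical assay compound 3 gives 122000 nM.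

The compounds shown leave open whether the shifts in the A-375 assay and the physicochemical assay follow from the ring, its two methyl groups or its defined stereocentre. A morpholin-4-yl group or a piperazin-1-yl group without methyl groups on this same aromatic carbon would help separate these parts, and would show whether the two shifts can be pulled apart.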